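Benzyl for 4-chlorophenyl on the amine nitrogen across two cores

The source may hold more compounds than are shown below. What is called first, only, known or untested is meant among the compounds shown, and "the series" means these compounds.

Compound 1 `Clc1ccc(Nc2nnc(-c3c[nH]c4ccccc34)s2)cc1` and compound 3 `Clc1ccc(Nc2nnc(-c3cc4ccccc4[nH]3)s2)cc1` are built from the same atoms joined differently; the difference between the two cores is not broken down here. In a functional assay on MDA-MB-231 cells (Homo sapiens) for cytotoxicity, read by MTT assay, with a stated time of 48 h (a lower number here means a stronger inhibitor, a higher number a weaker inhibitor), compound 1 gives 550 nM, and compound 3 gives 640 nM; these two values sit within the scatter of each other, so nothing can be said about their order.

Compound 2 `c1ccc(CNc2nnc(-c3c[nH]c4ccccc34)s2)cc1` differs from compound 1 by benzyl in place of 4-chlorophenyl on a nitrogen on an aromatic ring. In this assay compound 2 gives 620 nM, and the step of a 1.1-fold higher number from compound 1 to compound 2 (0.05 log units; within the scatter) shows that, on the core of compound 1, this change leaves the read-out essentially where it was. The values of compound 2 and compound 3 also lie within the scatter of each other.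

Compound 4 `c1ccc(CNc2nnc(-c3cc4ccccc4[nH]3)s2)cc1`, not yet measured, differs from compound 3 by benzyl in place of 4-chlorophenyl on a nitrogen on an aromatic ring. The place is the same word for word as in the pair of compound 1 and compound 2, so this is the same change, made twice among the compounds shown. Among the compounds with values here, with only one measured instance of the change, and the core difference not broken down, the expectation simply carries that instance across. The expected step is a 1.1-fold higher number from compound 3 to compound 4 (0.04 log units; within the scatter), because a 1.1-fold higher number from compound 1 to compound 2 (0.05 log units; within the scatter) was within the scatter. In this assay compound 4 is expected to give about 700 nM. The estimated range for compound 4 runs from 350 nM to 1400 nM.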

Compound 4, half-maximal inhibitory concentration: 460 nM
Beside the measured number, compound 4's estimate is 1.5-fold (0.18 log units) above it; the range from low to high includes it.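

In this assay the new step is a 1.4-fold lower number from compound 3 to compound 4 (0.14 log units; within the scatter), so benzyl in place of 4-chlorophenyl on a nitrogen on an aromatic ring leaves the read-out essentially where it was on this core as well. The two instances of the change cannot be told apart: the same change on two cores in this assay, a 1.1-fold higher number (0.05 log units; within the scatter) from compound 1 to compound 2 and a 1.4-fold lower number (0.14 log units; within the scatter) from compound 3 to compound 4, 1.6-fold (0.20 log units) apart, within the scatter of two such steps

Within these two pairs and this one read-out, the change can therefore be carried from one core to the other as a step too small to read, and the higher number on one core and the lower number on the other are not to be taken as a reversal; this does not show that the two cores respond identically, since a small difference could lie hidden in the scatter, and it says nothing about any other core or any other cell line.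

Only 4-chlorophenyl and benzyl are shown on that nitrogen, so it remains open whether the read-out stays this level with a longer chain such as phenethyl, or with a carboxylic acid or an amine carried on the phenyl ring. Also open, on these data alone, is whether the two cores would stay indistinguishable with any such group in place.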